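Compound 3 and the step to a fluoroethenyl amide

The source may report more compounds than this note shows. Statements on the series, on what has been measured and on what is new or still open speak of the compounds shown alone.

Compound 1 `CC/C=C/C(=O)Nc1cccc(Oc2nc(Nc3ccn(C)n3)nc3c2CSCC3)c1` gives 36800 nM
Compound 2 `CC(C)=CC(=O)Nc1cccc(Oc2nc(Nc3ccn(C)n3)nc3c2CSCC3)c1` gives 44200 nM
Compound 3 `CC/C=C/C(=O)Nc1cccc(Oc2nc(Nc3cccc(OC)c3)nc3c2CSCC3)c1` gives 17200 nM

Compound 3 at 17200 nM holds the lowest number of the three in a functional assay on A549 cells (Homo sapiens) for antiproliferative activity, read by MTT assay, with a stated time of 72 h (a higher number here means a weaker inhibitor, a lower number a stronger inhibitor), and stands clear of both others. The change to compound 4 `C=C(F)C(=O)Nc1cccc(Oc2nc(Nc3cccc(OC)c3)nc3c2CSCC3)c1` is 1-fluoroethenyl in place of but-1-en-1-yl on a carbonyl carbon and reads 1-fluoroethenyl in place of but-1-en-1-yl on a carbonyl carbon. Going by the values given here, only one measured step sits on that carbonyl carbon, namely a 1.2-fold higher number from compound 1 to compound 2 (0.08 log units; within the scatter) and it does not involve 1-fluoroethenyl. The other step, a 2.1-fold lower number from compound 1 to compound 3 (0.33 log units; beyond the scatter) and lies on a nitrogen on an aromatic ring instead. Neither fixes a size, so a modest move to a lower number is expected, with wide uncertainty. The expected step is a 2.2-fold lower number from compound 3 to compound 4 (0.33 log units; beyond the scatter) and remains an estimate. In this assay compound 4 is estimated at 8000 nM within an expected range of 1500 nM to 30000 nM for now.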

Compound 4, half-maximal inhibitory concentration: 29600 nM
Compound 4: the middle estimate sits 3.7-fold (0.57 log units) below what was measured; low and high end bracket the measured number.
By their numbers in this assay, from the lowest: compounds 3, 4, 1 and 2 (each within the scatter of the next, the first and the last beyond it).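

In this assay, going by these compounds alone, 1-fluoroethenyl in place of but-1-en-1-yl on a carbonyl carbon gives a 1.7-fold higher number from compound 3 to compound 4 (0.24 log units; within the scatter), the first measured step at this position with fluorine in the entering group. Like a 1.2-fold higher number from compound 1 to compound 2 (0.08 log units; within the scatter), it stays within the scatter, so this now holds with 3-methoxyphenyl on the nitrogen as well as with 1-methyl-1H-pyrazol-3-yl. No measurement is available here that would account for this result. Still open, as far as these compounds go, is how a saturated ethyl group or an amine-bearing chain would read on this carbonyl carbon, and whether 1-fluoroethenyl reads the same with 1-methyl-1H-pyrazol-3-yl.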